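This account rests on a few compounds, and the source may have more. Where it says the series, first, only, none or still open, it means among the compounds named here.

Compound 1 `CCc1ccccc1NC(=O)N[C@H](C)c1ccccc1`: in an ADME assay on the whole organism with Oryza sativa as the target, tested at 0.1 uM (a lower number here means a stronger effect, a higher number a weaker effect of the compound at the concentration tested), compound 1 gives 101%
Compound 2 `CCc1ccccc1NC(=O)N[C@@H](C)c1ccccc1`: in this assay compound 2 gives 100%
Compound 3 `CCc1cccc(NC(=O)N[C@H](C)c2ccccc2)c1`: in this assay compound 3 gives 97%

The three measured compounds sit close together in this assay. Compound 2 stands second highest of the three numbers; its nearest neighbour is compound 1, and the step of a number 1 percentage points lower from compound 1 to compound 2 (within the scatter) is within the scatter, which fits (the fact that compounds 1 and 2 differ only in the configuration as drawn). Compound 3, the furthest from compound 2 on these numbers, is also within the scatter of it, so the three values show no difference that can be read.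

Compound 4 `C[C@H](NC(=O)Nc1ccccc1C(F)(F)F)c1ccccc1` is the compound not yet measured. It differs from compound 2 as follows: trifluoromethyl in place of ethyl on an aromatic carbon. Within the data shown here, no measured step concerns this change, since the only step that can be compared is a change of configuration alone; the ethyl to trifluoromethyl exchange has no counterpart among the measured compounds. With all three measured values lying within the scatter of one another, the step of a number 2 percentage points lower from compound 2 to compound 4 (within the scatter) is expected to be none beyond the scatter. Compound 4 is therefore estimated at 98%, with a range from 85% to 106%.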

Compound 4, a percentage reported as activity, at one concentration (the size of the read-out at that concentration, not a potency): 97%
Beside the measured number, compound 4's estimate is 1 percentage points above it, and the stated range covers the measured number.
By their numbers in this assay, from the lowest: compounds 3, 4, 2 and 1 (each within the scatter of the next).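

In this assay, placing trifluoromethyl in place of ethyl on an aromatic carbon, ortho to a large group, gives a number 3 percentage points lower from compound 2 to compound 4 (within the scatter). Among these compounds, until now, the only comparable step concerned configuration; this one shows that, for this pair, a change of group at this position, with four heavy atoms entering where two leave, produces no difference that can be read. Nothing known about these compounds bears on this exchange.

As far as these compounds go, whether an amine, a carboxylic acid or a longer chain on this aromatic carbon would give a step beyond the scatter in this assay remains open. Also open, from the compounds shown here alone, is whether the same exchange would read alike in the opposite configuration as drawn.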